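This account rests on a few compounds, and the source may have more. Where it says the series, first, only, none or still open, it means among the compounds named here.

Compound 1 `CC(C)c1ccc(NC(=O)C2CCN(C/C=C/c3ccccc3)CC2)cc1` gives 5200 nM
Compound 2 `COc1ccccc1NC(=O)C1CCN(C/C=C/c2ccccc2)CC1` gives 71200 nM

Both values come from a functional assay on MGC-803 cells (Homo sapiens) for inhibition, read by MTT assay, with a stated time of 72 h (a higher number here means a weaker inhibitor, a lower number a stronger inhibitor), and compound 2 has the higher number of the two, which makes it the weaker inhibitor of this pair. Compound 3 `O=C(Nc1cccc(F)c1)C1CCN(C/C=C/c2ccccc2)CC1` keeps the core of compound 2 and changes one group: 3-fluorophenyl in place of 2-methoxyphenyl on an amide-type nitrogen that is, 3-fluorophenyl in place of 2-methoxyphenyl on an amide-type nitrogen.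

Among the measured compounds shown here, only one measured step bears on this place, a 14-fold higher number from compound 1 to compound 2 (1.14 log units; beyond the scatter) and it is large, so the group on this nitrogen can clearly move the number. For the measured compounds named here, it is still a single step, and no measured compound carries the 3-fluorophenyl group, so the evidence is thin. Going by the values given here, with compound 2 at 71200 nM as the higher of only two numbers, a moderate move toward a lower number seems more likely than a further rise. The expected change is a 3.6-fold lower number from compound 2 to compound 3 (0.55 log units; beyond the scatter) and it remains uncertain. In this assay the estimated value for compound 3 is 20000 nM with 6000 nM to 70000 nM as the expected range.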

Compound 3, half-maximal inhibitory concentration: 23300 nM
Beside the measured number, compound 3's estimate is 1.2-fold (0.07 log units) below it; low and high end bracket the measured number.
By their numbers in this assay, from the lowest: compound 1; then compound 3; then compound 2.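

In this assay, 3-fluorophenyl in place of 2-methoxyphenyl gives a 3.1-fold lower number from compound 2 to compound 3 (0.49 log units; beyond the scatter), while 3-fluorophenyl in place of 4-isopropylphenyl gives a 4.5-fold higher number from compound 1 to compound 3 (0.65 log units; beyond the scatter). With a third group on the amide-type nitrogen, the position no longer rests on a single contrast: the numbers form a graded series in which compound 3 sits between the other two, both of its steps are beyond the scatter, and compound 1 remains the strongest inhibitor of the three. Nothing available explains why the groups fall in this order.

The three phenyl groups differ both in what they carry and in the number in their names, so these steps cannot show how much each of those two differences contributes. A plain phenyl group, or 4-fluorophenyl and 2-fluorophenyl set against 3-fluorophenyl, would separate them, and a cyclohexyl group on the same nitrogen would test whether an aromatic ring is needed there at all.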